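Compound 1 trades 2,2-difluoroethoxy for cyclopropylmethoxy

A few compounds are considered here, and "the series" means these few. Any claim that something is new, unique, unknown or untested is made for them only; others in the source may bear on it.

Values so far in a physicochemical assay for lipophilicity, at pH 7.4 (a higher number here means a more lipophilic compound, a lower number a more polar compound), are these
compound 1 `O=C(O)Cn1nc(Cc2nc3cc(Cl)c(OCC(F)F)cc3[nH]2)c2ccccc2c1=O` gives 1.97
compound 2 `O=C(O)Cn1nc(Cc2cn3cc(OCC4CC4)c(Cl)cc3n2)c2ccccc2c1=O` gives 2.27
compound 3 `COc1cc(OC)c(NC(=O)Cn2nc(CC(=O)O)c3ccccc32)cc1Cl` gives 1.86

Compound 1 at 1.97 is second highest of these three numbers, yet its gaps to compound 3 and to compound 2 both lie within the usual scatter of repeated measurements. The next compound to be measured is compound 4 `O=C(O)Cn1nc(Cc2nc3cc(Cl)c(OCC4CC4)cc3[nH]2)c2ccccc2c1=O` and it keeps the core of compound 1 with one change: cyclopropyl in place of difluoromethyl on a saturated chain carbon bound to an oxygen on an aromatic ring in which cyclopropyl takes the place of difluoromethyl on a saturated chain carbon bound to an oxygen on an aromatic ring. Read one bond further out, 2,2-difluoroethoxy becomes cyclopropylmethoxy.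

For the measured compounds named here, no measured pair isolates this change, so the evidence is thin. The nearest pointer is compound 2 at 2.27 which carries cyclopropylmethoxy on a different core. A small upward move in this assay is therefore expected, and the estimated a number 0.28 log units higher from compound 1 to compound 4 (within the scatter) is close to the size of the scatter. For compound 4 the estimated value is 2.25 with an expected range from 1.9 to 2.6 before any measurement.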

Compound 4, distribution coefficient: 2.21
Compound 4: the middle estimate sits 0.04 log units above what was measured; the measured number falls inside the stated range.
By their numbers in this assay, from the lowest: compounds 3, 1, 4 and 2 (each within the scatter of the next, the first and the last beyond it).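

For the compounds shown here, for the first time, the swap of difluoromethyl for cyclopropyl on a saturated chain carbon bound to an oxygen on an aromatic ring can be read on its own, because compound 1 and compound 4 differ only in that place, and this assay gives a number 0.24 log units higher from compound 1 to compound 4 (within the scatter) for it. Two fluorine atoms and one carbon thus give way to a three-membered carbon ring of the same heavy-atom count, and at this position the assay does not separate the two groups. No measurement shown here explains this step.

The compounds shown leave open whether a group of another kind at this place, such as an amine or a longer chain, would stand apart from these two. From the compounds shown here alone, whether the same swap reads alike on a different core also remains open.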